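The source may hold more compounds than are shown below. What is called first, only, known or untested is meant among the compounds shown, and "the series" means these compounds.

In a functional assay on MCF7 cells (Homo sapiens) for antiproliferative activity, read by sulforhodamine B assay, with a stated time of 72 h (on this read-out higher numbers stand for weaker inhibition and lower numbers for stronger inhibition), compound 1 `COc1ccc2nc(Cl)c(/C=C\c3cc(C(F)(F)F)cc(C(F)(F)F)c3)cc2c1` gives 4700 nM and compound 2 `FC(F)(F)c1cc(/C=C\c2cc3ccccc3nc2Cl)cc(C(F)(F)F)c1` gives 7460 nM. Within the data shown here, compound 2 therefore stands within the scatter of compound 1, the only other compound measured so far. Compound 3 `FC(F)(F)c1cc(/C=C\c2cc3ccc(Cl)cc3nc2Cl)cc(C(F)(F)F)c1` differs from compound 2 in one place, with chloro in place of hydrogen on an aromatic carbon. Among the measured compounds shown here, only one measured step bears on this change, and it involves a different group: a 1.6-fold higher number from compound 1 to compound 2 (0.20 log units; within the scatter), with hydrogen in place of methoxy on an aromatic carbon. For the measured compounds named here, that step stays within the scatter, but it is a loose guide, as no measured compound here shows the effect of adding chloro. No change beyond the scatter is therefore expected in this assay, and the estimated step is a 1.2-fold lower number from compound 2 to compound 3 (0.09 log units; within the scatter). For compound 3, the expected value is 6000 nM, with an estimated range of 2200 nM to 16000 nM.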

Compound 3, half-maximal inhibitory concentration: 41700 nM
Beside the measured number, compound 3's estimate is 7.0-fold (0.84 log units) below it; measured number outside the range, above it.
By their numbers in this assay, from the lowest: compounds 1 and 2 (each within the scatter of the next); then compound 3.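

In this assay, among these compounds, chloro on this aromatic carbon, on the six-membered ring of carbon only that is part of the fused system, gives the first single change here to pass the scatter: a 5.6-fold higher number from compound 2 to compound 3 (0.75 log units; beyond the scatter), which means weaker inhibition. The earlier step, hydrogen in place of methoxy on an aromatic carbon, gave only a 1.6-fold higher number from compound 1 to compound 2 (0.20 log units; within the scatter), so it offered no sign that one added atom could weaken inhibition this much. Nothing measured here explains why this chloro has this effect.

The compounds shown leave open whether the weakening belongs to chloro itself or would also come with another group on this carbon, such as fluoro or an amine. They also leave open whether chloro on a different carbon of this ring would do the same.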